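Two Measured Compounds and a Chloro Swap

The source may hold more compounds than are shown below. What is called first, only, known or untested is meant among the compounds shown, and "the series" means these compounds.

Values in a functional assay on A549 cells (Homo sapiens) for antiproliferative activity, read by MTT assay, with a stated time of 72 h; a higher number here means a weaker inhibitor, a lower number a stronger inhibitor:
- compound 1 `CCOc1ccc(-c2ccc3ncn(-c4cc(OC)c(OC)c(OC)c4)c3c2)cc1` gives 8550 nM
- compound 2 `COc1ccccc1-c1ccc2ncn(-c3cc(OC)c(OC)c(OC)c3)c2c1` gives 4320 nM

Only these two compounds have been measured, and compound 2 stands level with compound 1 within the scatter. Compound 3 `COc1cc(-n2cnc3ccc(-c4ccccc4Cl)cc32)cc(OC)c1OC` is the 2-chlorophenyl counterpart of compound 2, with chloro in place of methoxy on an aromatic carbon. For the measured compounds named here, the one measured step, a 2.0-fold lower number from compound 1 to compound 2 (0.30 log units; within the scatter), replaces 4-ethoxyphenyl with 2-methoxyphenyl, and it does not test this swap directly. In this assay, the expected step is a 1.2-fold higher number from compound 2 to compound 3 (0.06 log units; within the scatter), with no change estimated beyond the scatter. Compound 3 is expected at 5000 nM, with an estimated range from 1800 nM to 14000 nM.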

Compound 3, half-maximal inhibitory concentration: > 10000 nM
Compound 3: a limit, no number; the forecaster's own chance of this, stated with the estimate: 10%; middle value at least 2.0-fold (0.30 log units) away from the limit.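

On this aromatic carbon, chloro is not a neutral replacement for methoxy in this assay: the swap gives an at least 2.3-fold higher number from compound 2 to compound 3 (0.36 log units; beyond the scatter), the only step among these compounds that is printed as beyond the scatter. The change to 2-chlorophenyl gives an at least 1.1-fold higher number from compound 1 to compound 3 (0.06 log units; that floor lies within the scatter), so compound 3 cannot be separated from compound 1 on this reading. The value of compound 3 is a limit of the assay and not a number: the limit of > 10000 nM in this assay, at which 1 of the 3 values shown sits.

Going by these compounds, how far compound 3 lies past that limit remains open. Also open, on these data alone, is how an amine or a hydroxy group would read on this carbon, compared with methoxy and chloro.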